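From Pyrazole to Dimethyltriazole on the Amide Chain

This account rests on a few compounds, and the source may have more. Where it says the series, first, only, none or still open, it means among the compounds named here.

Among the measured compounds shown here, compound 1 `C[C@@H]1CN(c2sc(C(F)(F)F)nc2-c2nc3ccccc3[nH]2)CCN1C(=O)Cn1cccn1` gives 191 nM in a functional assay on Venous blood for antagonist activity at C-X-C chemokine receptor type 3 (Homo sapiens), read by flow cytometry, with a stated time of 30 min, in the presence of a further agent that is not named here (on this read-out lower numbers stand for stronger inhibition and higher numbers for weaker inhibition), the lowest of the two numbers measured so far, with compound 2 `Cc1nn(CC(=O)N2CCN(c3sc(C(F)(F)F)nc3-c3nc4ccccc4[nH]3)C[C@H]2C)cc1CN(C)C` nearest at 330 nM. The change from compound 1 to compound 3 `Cc1nc(C)n(CC(=O)N2CCN(c3sc(C(F)(F)F)nc3-c3nc4ccccc4[nH]3)C[C@H]2C)n1` is 3,5-dimethyl-1H-1,2,4-triazol-1-yl in place of 1H-pyrazol-1-yl on a saturated chain carbon bound to a carbonyl carbon. For the measured compounds named here, the only measured step at the same place, a 1.7-fold higher number from compound 1 to compound 2 (0.24 log units; within the scatter), bears on this change and stayed within the scatter. Compound 3 is therefore expected to show a step of a 1.3-fold higher number from compound 1 to compound 3 (0.12 log units; within the scatter), nothing beyond the scatter in either direction. Compound 3 is estimated at 250 nM, within a range from 110 nM to 600 nM.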

Compound 3, half-maximal inhibitory concentration in the C-X-C chemokine receptor type 3 assay: 237 nM
Estimate against measurement, compound 3: 1.1-fold (0.02 log units) above, within the range that was stated.
By their numbers in the C-X-C chemokine receptor type 3 assay, from the lowest: compounds 1, 3 and 2 (each within the scatter of the next).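

In the C-X-C chemokine receptor type 3 assay the steps of a 1.2-fold higher number from compound 1 to compound 3 (0.09 log units; within the scatter) and of a 1.4-fold lower number from compound 2 to compound 3 (0.14 log units; within the scatter) show that this place, on a saturated chain carbon bound to a carbonyl carbon, has taken a third group with no step beyond the scatter. In a physicochemical assay for solubility, in simulated intestinal fluid (on this read-out lower numbers stand for lower solubility and higher numbers for higher solubility), compound 1 gives 734 ug/mL as a measured number. In the physicochemical assay compound 3 gives > 850 ug/mL as a limit of the assay and not as a number: the limit of > 850 ug/mL in the physicochemical assay, at which 1 of the 2 values shown sits.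

From the compounds shown here alone, whether a carboxylic acid or a longer chain at this place would give in the C-X-C chemokine receptor type 3 assay a step beyond the scatter stays open. Going by these compounds, how far compound 3 lies from compound 1 in the physicochemical assay also stays open.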